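A few compounds are considered here, and "the series" means these few. Any claim that something is new, unique, unknown or untested is made for them only; others in the source may bear on it.

Compound 1, `CCO/C=N/C1=C(C#N)C(c2ccc(F)cc2)C2=C(CC(C)(C)CC2=O)N1c1ccc(S(N)(=O)=O)cc1`, gives in a functional assay on MCF7 cells (Homo sapiens) for cytotoxicity, read by sulforhodamine B assay, with a stated time of 48 h (on this read-out higher numbers stand for weaker inhibition and lower numbers for stronger inhibition), a value of 67300 nM. Compound 2, `CC1(C)CC(=O)C2=C(C1)N(c1ccc(S(N)(=O)=O)cc1)C(NC(=O)CCl)=C(C#N)C2c1ccc(F)cc1`, gives in this assay a value of 70800 nM. Compound 3, `CCNC(=S)NC1=C(C#N)C(c2ccc(F)cc2)C2=C(CC(C)(C)CC2=O)N1c1ccc(S(N)(=O)=O)cc1`, reaches in this assay only a limit of the assay, > 100000 nM.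

Compound 3 therefore has no number of its own; the values of compound 1 and compound 2 show where the floor of its step lies, and an at least 1.4-fold higher number from compound 1 to compound 3 (0.17 log units; that floor lies within the scatter) and an at least 1.4-fold higher number from compound 2 to compound 3 (0.14 log units; that floor lies within the scatter) both say that this floor is within the scatter. Compound 4, `CC1(C)CC(=O)C2=C(C1)N(c1ccc(S(N)(=O)=O)cc1)C(N1C(=O)CCC1=O)=C(C#N)C2c1ccc(F)cc1`, is not yet measured. It differs from compound 3 in one place: a group of 7 heavy atoms (4 carbon, 1 nitrogen, 2 oxygen; one five-membered non-aromatic ring with 1 hetero atom) in place of a group of 6 heavy atoms (3 carbon, 2 nitrogen, 1 sulfur; no ring), on a double-bonded ring carbon. The steps already seen on that same carbon all concern swaps of a small group there, namely a 1.1-fold higher number from compound 1 to compound 2 (0.02 log units; within the scatter), an at least 1.4-fold higher number from compound 1 to compound 3 (0.17 log units; that floor lies within the scatter) and an at least 1.4-fold higher number from compound 2 to compound 3 (0.14 log units; that floor lies within the scatter), none of them beyond the scatter. For compound 4 in this assay a step no larger than the scatter is therefore expected, with no clear direction. The expected number for compound 4 is 90000 nM, within a range from 40000 nM to 200000 nM. From compound 3 this estimate means an at least 1.1-fold lower number from compound 3 to compound 4 (0.04 log units; that floor lies within the scatter), an expected step within the scatter.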

Compound 4, half-maximal inhibitory concentration: 94100 nM
Compound 4: the middle estimate sits 1.0-fold (0.02 log units) below what was measured, within the range that was stated.
By their numbers in this assay, from the lowest: compounds 1, 2 and 4 (each within the scatter of the next). At a limit, above all of these: compound 3.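

Unlike the open groups of compound 1, compound 2 and compound 3, the 2,5-dioxopyrrolidin-1-yl group puts a five-membered ring on this double-bonded ring carbon, and in this assay this leaves the number within the scatter: a 1.3-fold higher number from compound 2 to compound 4 (0.12 log units; within the scatter) and a 1.4-fold higher number from compound 1 to compound 4 (0.15 log units; within the scatter). Against compound 3 only a floor can be read, an at least 1.0-fold lower number from compound 3 to compound 4 (0.02 log units; that floor lies within the scatter). Compound 3 stands at a limit of the assay and has no number of its own: the limit of > 100000 nM in this assay, at which 1 of the 4 values shown sits.

The compounds shown leave open whether any group on this carbon, such as a free amine or a carboxylic acid, moves the number beyond the scatter. They also leave open whether replacing the 4-fluorophenyl group or the 4-sulfamoylphenyl group on the shared core would do so.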